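Carboxy in Place of Fluoro on the Phenyl Ring

The compounds below may be only part of what the source reports. "The series", "measured", "known", "first", "only" and "open" are said of these compounds alone.

Compound 1, `Cn1c(-c2ccc(F)cc2)nc2c(NC3CCCC3)ncnc21`, shows the lowest of the two numbers measured in an assay on CHO cells for displacement of a labelled ligand from adenosine receptor A1 (Homo sapiens), read by scintillation counting, with a stated time of 3 h; on this read-out higher numbers stand for weaker inhibition and lower numbers for stronger inhibition; in that test compound 1 gives 6.2 nM. Its nearest companion is compound 2, `CCCn1c(-c2ccccc2)nc2c(NC3CCCC3)ncnc21`, and in this assay compound 2 gives 10 nM. The gap between the two lies within the usual scatter, so neither can be called the tighter binder on these numbers alone. The two compounds also differ at more than one place, so their pair says nothing about any single change.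

The untested compound 3, `Cn1c(-c2ccc(C(=O)O)cc2)nc2c(NC3CCCC3)ncnc21`, keeps the rest of compound 1 unchanged and differs only by carboxy in place of fluoro on an aromatic carbon. Among the measured compounds shown here, no measured pair shows this change, so there is no step to lean on. The step of an 8.1-fold higher number from compound 1 to compound 3 (0.91 log units; beyond the scatter) is expected to be a loss of moderate size that reaches beyond the scatter. Compound 3 is therefore estimated to give 50 nM in this assay, with a range from 8 nM to 300 nM.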

Compound 3, inhibition constant: 54000 nM
The estimate for compound 3 lay 1100-fold (3.03 log units) below the measured number; measured number above the stated range.
By their numbers in this assay, from the lowest: compounds 1 and 2 (each within the scatter of the next); then compound 3.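

In this assay, carboxy in place of fluoro on an aromatic carbon, para to a large group, brings an 8700-fold higher number from compound 1 to compound 3 (3.94 log units; beyond the scatter), a large step beyond the scatter. The earlier pair, compound 1 and compound 2, could not show this: their numbers lie within the scatter of each other, and they differ at more than one place, so they spoke to no single change. Here the rest of compound 1 stays unchanged, which ties the whole step to this one exchange at this one carbon, where a single fluorine gives way to three heavy atoms, with a hydrogen-bond donor and a hydrogen-bond acceptor entering; nothing available explains why the number rises so far.

The compounds shown leave open whether the step belongs to carboxy itself or would also appear with a methyl ester, a primary amide or a hydroxymethyl group on the same carbon. They also leave open whether carboxy would bring a step of similar size on compound 2, which carries no fluoro at that place.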